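The source may report more compounds than this note shows. Statements on the series, on what has been measured and on what is new or still open speak of the compounds shown alone.

Of the compounds shown here, two built on a shared core have so far been measured in an assay on cells for displacement of a labelled ligand from Glucagon receptor (Homo sapiens), in the presence of a further agent that is not named here; on this read-out higher numbers stand for weaker inhibition and lower numbers for stronger inhibition. Compound 1, `O=C(O)CCNC(=O)c1ccc(C(Oc2ccc(-n3cc(C(F)(F)F)cn3)cc2)C2CCC2)cc1`, carries a cyclobutyl group on the saturated chain carbon bound to an aromatic carbon and an oxygen on an aromatic ring, and in this assay compound 1 gives 700 nM. Compound 2, `CCC(Oc1ccc(-n2cc(C(F)(F)F)cn2)cc1)c1ccc(C(=O)NCCC(=O)O)cc1`, carries an ethyl group at that place, and in this assay compound 2 gives 1400 nM. The pair is separated by a 2.0-fold higher number from compound 1 to compound 2 (0.30 log units; within the scatter), so on the numbers shown compound 2 stands at one end of two values that cannot be told apart.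

Compound 3, `CC(C)(C)C(Oc1ccc(-n2cc(C(F)(F)F)cn2)cc1)c1ccc(C(=O)NCCC(=O)O)cc1`, continues the series with one change: tert-butyl in place of ethyl on a saturated chain carbon bound to an aromatic carbon and an oxygen on an aromatic ring. Within the data shown here, only one measured step bears on this exchange of one small alkyl group for another at the same place, the step of a 2.0-fold higher number from compound 1 to compound 2 (0.30 log units; within the scatter), and it stayed within the scatter. On that basis the expected step is a 1.4-fold lower number from compound 2 to compound 3 (0.15 log units; within the scatter), a shift not clearly beyond the scatter. Compound 3 is therefore estimated at 1000 nM, with a range from 400 nM to 2500 nM.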

Compound 3, inhibition constant: 170 nM
Compound 3: the middle estimate sits 5.9-fold (0.77 log units) above what was measured; measured number outside the range, below it.
By their numbers in this assay, from the lowest: compound 3; then compounds 1 and 2 (each within the scatter of the next).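

In this assay, this position now shows a clear response that the earlier pair did not: tert-butyl in place of ethyl gives an 8.2-fold lower number from compound 2 to compound 3 (0.92 log units; beyond the scatter), a step beyond the scatter, whereas the cyclobutyl and ethyl compounds could not be told apart. The same group also separates from cyclobutyl, with a 4.1-fold lower number from compound 1 to compound 3 (0.61 log units; beyond the scatter), so this place on the saturated chain carbon does distinguish between alkyl groups, and compound 3 has the lowest number of the three. Nothing given here offers a reason for this difference.

From the compounds shown here alone, all three groups at this place are plain saturated carbon groups, so it remains open whether the number would fall further, hold or rise with a phenyl ring, a methoxy group or a chain ending in an amine. The rest of the molecule is also the same in all three compounds, which leaves open whether the tert-butyl step would carry over if, for example, a nitrile stood in place of the trifluoromethyl group.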